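Swapping Hydroxymethyl for Dimethylamino on a Chain

The source may report more compounds than this note shows. Statements on the series, on what has been measured and on what is new or still open speak of the compounds shown alone.

Compound 1 `Cn1ncc(Cl)c1-c1cc(C(=O)N[C@@H]2CN[C@H](CCCO)C[C@H]2c2ccc(Cl)c(Cl)c2)oc1Cl`: 510 nM
Compound 2 `CNC(=O)C[C@@H]1C[C@@H](c2ccc(F)c(F)c2)[C@H](NC(=O)c2cc(-c3c(Cl)cnn3C)c(Cl)o2)CN1`: 1100 nM

In a functional assay on HCT-116 cells (Homo sapiens) for antiproliferative activity, read by sulforhodamine B assay, with a stated time of 72 h (a higher number here means a weaker inhibitor, a lower number a stronger inhibitor), compound 1 gives 510 nM, the lower of the two numbers. Compound 2 gives 1100 nM, and that gap lies beyond the usual scatter. Compound 3 `CN(C)CC[C@@H]1C[C@@H](c2ccc(Cl)c(Cl)c2)[C@H](NC(=O)c2cc(-c3c(Cl)cnn3C)c(Cl)o2)CN1` has not yet been measured. Relative to compound 1, it has dimethylamino in place of hydroxymethyl on a saturated chain carbon, two bonds along the chain from a saturated ring carbon. Among the measured compounds shown here, no measured step shows what such a swap does, so in this assay no clear shift in either direction is expected. The expected step is a 1.1-fold lower number from compound 1 to compound 3 (0.05 log units; within the scatter). For compound 3 the estimated value is 450 nM, with an expected range of 150 nM to 1300 nM.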

Compound 3, half-maximal inhibitory concentration: 1710 nM
Beside the measured number, compound 3's estimate is 3.8-fold (0.58 log units) below it; the measured number lies above the stated range.
By their numbers in this assay, from the lowest: compound 1; then compounds 2 and 3 (each within the scatter of the next).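

In this assay the change from 3-hydroxypropyl to 2-(dimethylamino)ethyl goes with a 3.4-fold higher number from compound 1 to compound 3 (0.53 log units; beyond the scatter) and so shows that this chain position responds to the group placed on it. Here, hydroxymethyl gives the stronger compound of this matched pair, with the shared core otherwise unchanged. Nothing measured here gives a reason for this shift.

The compounds shown do not separate the effect of losing hydroxymethyl from that of gaining dimethylamino. Going by these compounds, a primary amine, a methoxy group or a carboxylic acid on the same chain, or a longer chain, remains open.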